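A few compounds are considered here, and "the series" means these few. Any claim that something is new, unique, unknown or untested is made for them only; others in the source may bear on it.

Compound 1, `CO[C@H]1C(=O)N2C(C(=O)C(C)(C)C)=C(C)[C@@H](OC=O)S(=O)(=O)C12`, gives a value in this assay that is a limit of the assay: < 0.5 h.
Compound 2, `CO[C@H]1C(=O)N2C(C(=O)C(C)(C)C)=C(C)[C@@H](OC(C)=O)S(=O)(=O)C12`, gives 6.3 h.
Compound 3, `CO[C@H]1C(=O)N2C(C(=O)C(C)(C)C)=C(C)[C@@H](OC(=O)c3ccccc3)S(=O)(=O)C12`, gives 24 h.

Among the measured compounds shown here, in a physicochemical assay, at pH 7.4 (on this read-out lower numbers stand for a shorter-lived compound and higher numbers for a longer-lived compound), compound 3 holds the highest of the two numbers measured so far; the nearest is compound 2, and the step of a 3.8-fold higher number from compound 2 to compound 3 (0.58 log units; beyond the scatter) lies beyond the scatter. For compound 1 only the limit of < 0.5 h in this assay, at which 1 of the 3 values shown sits, is known, so its distance from the others cannot be counted exactly.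

The next compound, compound 4, is `CO[C@H]1C(=O)N2C(C(=O)C(C)(C)C)=C(C)[C@@H](OC(=O)c3ccc4ccccc4c3)S(=O)(=O)C12`. It differs from compound 3 by naphthalen-2-yl in place of phenyl on a carbonyl carbon. For the measured compounds named here, three measured steps bear on this place: an at least 12-fold higher number from compound 1 to compound 2 (1.10 log units; beyond the scatter), an at least 48-fold higher number from compound 1 to compound 3 (1.68 log units; beyond the scatter) and a 3.8-fold higher number from compound 2 to compound 3 (0.58 log units; beyond the scatter). Each time a larger group was put on that carbonyl carbon, the number in this assay rose, and the move from methyl to phenyl was the smallest of the three. Naphthalen-2-yl is again a larger group than phenyl, so a further rise, modest in size and in the same direction, is expected in this assay.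

For compound 4 the expected value is therefore 45 h, with a range from 18 h to 110 h. The step this expectation implies is a 1.9-fold higher number from compound 3 to compound 4 (0.27 log units; within the scatter).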

Compound 4, half-life: 33 h
The estimate for compound 4 lay 1.4-fold (0.13 log units) above the measured number; measured number inside the range.
By their numbers in this assay, from the lowest: compound 2; then compounds 3 and 4 (each within the scatter of the next). At a limit, below all of these: compound 1.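

The step to naphthalen-2-yl on this carbonyl carbon in this assay is a 1.4-fold higher number from compound 3 to compound 4 (0.14 log units; within the scatter), so the second aromatic ring does not separate these two compounds, and the rise seen from hydrogen through methyl to phenyl does not clearly continue past phenyl. Naphthalen-2-yl still stands clear of methyl, with a 5.2-fold higher number from compound 2 to compound 4 (0.72 log units; beyond the scatter), and of hydrogen, with an at least 66-fold higher number from compound 1 to compound 4 (1.81 log units; beyond the scatter). The comparison with hydrogen rests on compound 1, whose value is a limit and not an exact number: the limit of < 0.5 h in this assay, at which 1 of the 4 values shown sits.

As far as these compounds go, the groups on this carbonyl carbon so far are only hydrogen, methyl and rings of aromatic carbon, so it remains open how a longer chain, or a phenyl ring bearing an amine or a carboxylic acid, would behave. Whether size itself governs the half-life, or something else that changes along with it in this short series, cannot be told from these compounds.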